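Chloromethyl to hydroxymethyl at the same position

The source may report more compounds than this note shows. Statements on the series, on what has been measured and on what is new or still open speak of the compounds shown alone.

Compound 3 `O=c1cc(CCl)c2ccc(OCc3cccc(Br)c3)cc2o1` stands highest of the three numbers in an assay on isolated protein (strain Sprague-Dawley) for inhibition of Amine oxidase [flavin-containing] A (Rattus norvegicus), read by spectrophotometry, with a stated time of 5 min, tested at 10 uM (a higher number here means more inhibition at the concentration tested (going by the name of the read-out), a lower number less inhibition), where compound 3 gives 28%. Compound 1 `O=c1cc(O)c2ccc(OCc3cccc(Br)c3)cc2o1` gives 0%, and compound 2 `CCOc1cc(=O)oc2cc(OCc3cccc(Br)c3)ccc12` gives 2.5%; the change a number 2.5 percentage points higher from compound 1 to compound 2 (within the scatter) is within the scatter. The step of a number 28 percentage points higher from compound 1 to compound 3 (beyond the scatter) and the step of a number 25.5 percentage points higher from compound 2 to compound 3 (beyond the scatter) are both beyond the scatter and both point toward compound 3.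

Compound 4 `O=c1cc(CO)c2ccc(OCc3cccc(Br)c3)cc2o1` differs from compound 3 by hydroxy in place of chloro on a saturated chain carbon bound to an aromatic carbon, reading chloromethyl to hydroxymethyl one bond further out. Within the data shown here, no measured step makes this exact change; the closest is the step from compound 1, bearing a hydroxy, to compound 3, which was modest. The expected step of a number 16 percentage points lower from compound 3 to compound 4 (beyond the scatter) is a decrease, leaving compound 4 between compound 1 and compound 3. Compound 4 is estimated at 12% with range 0% to 30%.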

Compound 4, a percentage reported as inhibition, at one concentration (the size of the read-out at that concentration, not a potency): 49%
Estimate against measurement, compound 4: 37 percentage points below, and the stated range ends below it.
By their numbers in this assay, from the lowest: compounds 1 and 2 (each within the scatter of the next); then compound 3; then compound 4.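

Hydroxy in place of chloro on a saturated chain carbon bound to an aromatic carbon gives a number 21 percentage points higher from compound 3 to compound 4 (beyond the scatter) in this assay, so the chloro is not needed for inhibition among these compounds. Hydroxymethyl also stands well apart from the hydroxy and ethoxy on the aromatic carbon, with a number 49 percentage points higher from compound 1 to compound 4 (beyond the scatter) and a number 46.5 percentage points higher from compound 2 to compound 4 (beyond the scatter). Nothing available here accounts for these rises.

Open, going by these compounds, is whether an aminomethyl, a methoxymethyl or a longer chain ending in hydroxy at this place keeps the rise. Also open, on these data alone, is how hydroxymethyl fares with a different group in place of the bromobenzyl ether.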